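The source may report more compounds than this note shows. Statements on the series, on what has been measured and on what is new or still open speak of the compounds shown alone.

- Compound 1 `COc1ccc2c(c1)c(C(=O)C(=O)Nc1ccc(OC)nc1)cn2C(C)C` gives > 10000 nM as a limit
- Compound 2 `COc1ccc(NC(=O)C(=O)c2cn(C(C)C)c3ccccc23)cn1` gives 85 nM as a number
- Compound 3 `COCCn1cc(C(=O)C(=O)Nc2ccc(OC)nc2)c2cc(Cl)ccc21` gives > 10000 nM as a limit

These results come from a functional assay on FaDu cells (Homo sapiens) for cytotoxicity, read by MTT assay, with a stated time of 72 h (a lower number here means that less compound is tolerated, a higher number that more compound is tolerated), and compound 3 stands at the limit of > 10000 nM in this assay, at which 2 of the 3 values shown sit, as a limit, not a number. Compound 4 `COc1ccc(NC(=O)C(=O)c2cn(C(C)C)c3ccc(Cl)cc23)cn1` differs from compound 3 by isopropyl in place of 2-methoxyethyl on an aromatic nitrogen and nowhere else. Going by the values given here, no measured step makes this change. Among the compounds with values here, the one measured step, an at least 110-fold lower number from compound 1 to compound 2 (2.07 log units; beyond the scatter), is large but is hydrogen in place of methoxy on an aromatic carbon. Compound 2 carries isopropyl and gives 85 nM as its value. Compound 1 also carries isopropyl and goes against any simple pattern. A lower number is still expected, of large but uncertain size, and a limit remains possible. The estimate means an at least 25-fold lower number from compound 3 to compound 4 (1.39 log units; beyond the scatter) as the expected step. For compound 4 the expected value is 400 nM, with an estimated range of 40 nM to 5000 nM here.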

Compound 4, concentration lethal to 50% of the cells: > 10000 nM
Compound 4 was reported as a limit; the forecaster's own chance of this, stated with the estimate: 25%; middle value at least 25-fold (1.39 log units) away from the limit.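

In this assay, chloro in place of hydrogen on an aromatic carbon brings an at least 110-fold higher number from compound 2 to compound 4 (2.07 log units; beyond the scatter). Isopropyl on the aromatic nitrogen is therefore not enough by itself to give a number: among the isopropyl compounds, only compound 2, with hydrogen on that carbon, does, while compound 1 with methoxy and compound 4 with chloro do not. The steps from compound 1 and compound 3 to compound 4 cannot be read because both ends of each are limits: the limit of > 10000 nM in this assay, at which 3 of the 4 values shown sit.

From the compounds shown here alone, whether an amine or fluoro on that carbon would give a number stays open. So does the effect of 2-methoxyethyl or a longer chain on the nitrogen when that carbon carries hydrogen.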